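A few compounds are considered here, and "the series" means these few. Any claim that something is new, unique, unknown or untested is made for them only; others in the source may bear on it.

Compound 1 `O=C(Cn1c(=O)oc2ccccc21)NCc1ccccn1`: 38.7%
Compound 2 `O=C(Cn1c(=O)oc2ccccc21)NCc1cccs1`: 49.1%
Compound 3 `O=C(Cn1c(=O)oc2cc([N+](=O)[O-])ccc21)NCc1cccs1`: 41%

These three compounds have been tested in an ADME assay on RAW264.7 cells (Mus musculus) for cytotoxicity, read by MTT assay, with a stated time of 72 h, tested at 100 uM; on this read-out lower numbers stand for a weaker effect and higher numbers for a stronger effect at the one concentration tested; compound 4 `O=C(Cn1c(=O)oc2cc([N+](=O)[O-])ccc21)NCc1ccccn1` has not. Compound 4 differs from compound 3 by pyridin-2-yl in place of thiophen-2-yl on a saturated chain carbon bound to an amide-type nitrogen, the same change that turns compound 2 into compound 1, where it made a number 10.4 percentage points lower from compound 2 to compound 1 (beyond the scatter). The two cores differ by nitro in place of hydrogen on an aromatic carbon, a change that gave a number 8.1 percentage points lower from compound 2 to compound 3 (within the scatter). Since the two places are worded the same, the change is treated as the same one. The step expected in this assay is a number 9 percentage points lower from compound 3 to compound 4 (within the scatter), because the same change made a number 10.4 percentage points lower from compound 2 to compound 1 (beyond the scatter). Compound 4 is therefore expected to give 32% in this assay, estimated to fall between 22% and 42%.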

Compound 4, a percentage reported as inhibition, at one concentration (the size of the read-out at that concentration, not a potency): 33.4%
Beside the measured number, compound 4's estimate is 1.4 percentage points below it, within the range that was stated.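

In this assay, pyridin-2-yl in place of thiophen-2-yl gives a number 7.6 percentage points lower from compound 3 to compound 4 (within the scatter), and this agrees with the earlier step for the same change on the core without nitro: the same change on two cores in this assay, a number 10.4 percentage points lower (beyond the scatter) from compound 2 to compound 1 and a number 7.6 percentage points lower (within the scatter) from compound 3 to compound 4, 2.8 percentage points apart, within the scatter of two such steps. Nitro in place of hydrogen on an aromatic carbon gives a number 5.3 percentage points lower from compound 1 to compound 4 (within the scatter), and this also agrees with its earlier step: the same change on two cores in this assay, a number 8.1 percentage points lower (within the scatter) from compound 2 to compound 3 and a number 5.3 percentage points lower (within the scatter) from compound 1 to compound 4, 2.8 percentage points apart, within the scatter of two such steps. So each change carried across this one pair of cores with a similar size, but both new steps lie within the scatter, and two cores cannot show that either change would carry to a further core.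

The compounds shown leave open how a phenyl ring would compare with the two rings here, or a longer chain between the ring and the amide nitrogen. They also leave open whether an amine in place of nitro on the aromatic carbon would fit the same picture.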